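This account rests on a few compounds, and the source may have more. Where it says the series, first, only, none or still open, it means among the compounds named here.

Measured in a physicochemical assay for solubility, using the shake flask method, measured as kinetic solubility, with a stated time of 2 h, at pH 7.4 (on this read-out higher numbers stand for higher solubility and lower numbers for lower solubility), all three values being limits:
Compound 1 `CN(Cc1ccccc1)c1cc(C(=O)Nc2ccccc2)ncn1`: < 5000 nM
Compound 2 `CN(c1ccccc1)c1cc(C(=O)Nc2ccccc2)ncn1`: < 5000 nM
Compound 3 `CN(Cc1ccc(F)cc1)c1cc(C(=O)Nc2ccccc2)ncn1`: < 5000 nM

In this assay compound 3 gives < 5000 nM, which is a limit and not a number. It has no readable place among its neighbours, and the set as a whole shows (the limit of < 5000 nM in this assay, at which 3 of the 3 values shown sit).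

Compound 4 `CN(Cc1ccc(Cl)cc1)c1cc(C(=O)Nc2ccccc2)ncn1` carries chloro in place of fluoro on an aromatic carbon, para to a large group: chloro in place of fluoro on an aromatic carbon. The closest measured change at that carbon, fluoro in place of hydrogen, is a step that the two limits leave unreadable from compound 1 to compound 3. The two changes of the group on the nitrogen tell no more, one being a step that the two limits leave unreadable from compound 1 to compound 2 and the other step that the two limits leave unreadable from compound 2 to compound 3.

None of these steps has a readable size or direction, so they offer no ground for expecting a shift. No step beyond the scatter is expected in this assay, and the most likely report for compound 4 is another limit. The expected change is a step that the limit leaves unreadable from compound 3 to compound 4. Should a number be reported, compound 4 is estimated at 3000 nM, with an expected range from 1000 nM to 5000 nM.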

Compound 4, solubility: < 5000 nM
Compound 4 was reported as a limit (the forecaster's own chance of this, stated with the estimate: 90%); the middle value does not contradict the limit.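

In this assay compound 4 gives < 5000 nM as a limit and not a number. None of its steps to compound 1, compound 2 and compound 3 can be read, and the set stands thus: the limit of < 5000 nM in this assay, at which 4 of the 4 values shown sit.

The compounds shown leave open how far any of them lies from that limit, and whether changing the group on the nitrogen or on the aromatic carbon makes any difference.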